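A few compounds are considered here, and "the series" means these few. Any claim that something is new, unique, unknown or untested is made for them only; others in the source may bear on it.

Compound 1 `O=C(NNc1nc2ccccc2nc1Cc1ccccc1)c1ccccc1`: in an assay for inhibition of Amine oxidase [flavin-containing] A (Bos taurus), read by fluorescence, with a stated time of 60 min (a lower number here means a stronger inhibitor, a higher number a weaker inhibitor), compound 1 gives 78 nM.
Compound 2 `O=C(NNc1nc2ccccc2nc1Cc1ccccc1)c1ccc(Br)cc1`: in this assay compound 2 gives 74 nM.
Compound 3 `O=C(Cn1c(=O)c(Cc2ccccc2)nc2ccccc21)N/N=C/c1ccccc1`: in this assay compound 3 gives 3.1 nM.

Compound 3 stands lowest of the three in this assay; both compound 1 and compound 2 give clearly higher numbers, and in each case the gap lies beyond the scatter. Compound 4 `O=C(Cn1c(=O)c(Cc2ccccc2)nc2ccccc21)N/N=C/c1ccc([N+](=O)[O-])cc1` is the next compound, not yet measured in this assay. It differs from compound 3 in one place: nitro in place of hydrogen on an aromatic carbon, that is, phenyl to 4-nitrophenyl on the hydrazone end of the molecule.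

For the measured compounds named here, only one measured step speaks to a substituent in this position of a phenyl ring: a 1.1-fold lower number from compound 1 to compound 2 (0.02 log units; within the scatter), where bromo enters the benzoyl ring of a different series and the number hardly moves. Going by the values given here, no measured step involves nitro, and none involves the benzylidene phenyl of compound 3 itself. Compound 4 is therefore expected to show a step of a 1.2-fold lower number from compound 3 to compound 4 (0.09 log units; within the scatter) in this assay, not beyond the scatter. Compound 4 is estimated at 2.5 nM, with a range from 0.8 nM to 8 nM.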

Compound 4, half-maximal inhibitory concentration: 98 nM
For compound 4 the middle estimate is 39-fold (1.59 log units) below the measured one, outside the stated range (above it).
By their numbers in this assay, from the lowest: compound 3; then compounds 2, 1 and 4 (each within the scatter of the next).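

Phenyl to 4-nitrophenyl is not a quiet change in this assay: it brings a 32-fold higher number from compound 3 to compound 4 (1.50 log units; beyond the scatter) and so shows that the number for compound 3 responds strongly to a group placed on this aromatic carbon, para to a large group. For the compounds shown here, the only earlier step with a new group on a phenyl ring, a 1.1-fold lower number from compound 1 to compound 2 (0.02 log units; within the scatter) with bromo in a different series, gave no sign of this, so a flat step in that series does not carry over to this one. No measurement shown here accounts for the size of the new step.

Going by these compounds, it remains open whether this rise belongs to nitro itself or would follow any group at this place, which an amine or a methoxy group there would help to settle. On these data alone, it also remains open whether nitro would move the number as far on the benzoyl ring of compound 1.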